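Halogen swap on the aryl ring of compound 2

This account rests on a few compounds, and the source may have more. Where it says the series, first, only, none or still open, it means among the compounds named here.

Measured compounds:
compound 1 `Cc1ccc(CS(=O)(=O)/C(=C/c2c[nH]c3ccccc23)C(=O)c2ccc(Cl)cc2)cc1`: 25000 nM
compound 2 `O=C(/C(=C\c1ccc(F)cc1F)Sc1ccc(Br)cc1)c1ccc(Br)cc1`: 1000 nM
compound 3 `O=C(/C(=C\c1ccc(O)cc1O)S(=O)(=O)c1ccccc1Br)c1ccc(Br)cc1`: limit, > 100000 nM

Three compounds have been run in a functional assay on DU-145 cells (Homo sapiens) for inhibition, read by trypan blue exclusion, with a stated time of 96 h; a lower number here means a stronger inhibitor of growth, a higher number a weaker inhibitor of growth. Compound 2 gives 1000 nM, the lowest of the two numbers reported. Compound 1 gives 25000 nM, a gap from compound 2 that lies beyond the usual scatter. Among the compounds with values here, compound 3 returns only a limit, > 100000 nM, so no number is available for it; it is the one value sitting at the limit of > 100000 nM in this assay, at which 1 of the 3 values shown sits.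

Within the data shown here, no two of the measured compounds differ in a single place, so no measured step is available. Compound 4 `O=C(/C(=C\c1ccc(F)cc1Cl)Sc1ccc(Br)cc1)c1ccc(Br)cc1` is the next compound to be measured in this assay. It differs from compound 2 by chloro in place of fluoro on an aromatic carbon. Both halogens are single heavy atoms without donors or acceptors, and the rest of the molecule, including the thioether and both bromophenyl groups, is kept. A change of this kind is expected to move the number by no more than the scatter, in no set direction. The step from compound 2 to compound 4 is estimated as no change at the digits printed from compound 2 to compound 4 (within the scatter). Compound 4 is therefore expected to give 1000 nM, with a range from 400 nM to 3000 nM.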

Compound 4, concentration for 50% growth inhibition: 1000 nM
For compound 4 middle estimate and measured number coincide at the digits printed, and the stated range covers the measured number.
By their numbers in this assay, from the lowest: compounds 2 and 4 (each within the scatter of the next); then compound 1. At a limit, above all of these: compound 3.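

In this assay, within the data shown here, the exchange of 2,4-difluorophenyl for 2-chloro-4-fluorophenyl reads as no change at the digits printed from compound 2 to compound 4 (within the scatter), and this is the only step so far between compounds that differ in one place. It shows that this aromatic carbon, ortho to a large group and meta to a fluoro group, accepts chloro in place of fluoro without a shift beyond the scatter, with the thioether and both bromophenyl groups kept; compounds 1 and 3 could not show this, as each differs from compound 2 in more than one place, so steps to them cannot be read. Nothing measured here bears on why the values of compound 2 and compound 4 stay together.

Among these compounds, the one readable step exchanges one halogen for another, so it remains open whether an amine, a methoxy group or a carboxylic acid on this same carbon would also stay within the scatter of compound 2. Also open, on these data alone, is whether the other fluoro group of compound 4 can be exchanged for chloro or for a longer chain such as ethyl with a similarly small effect.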